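A few compounds are considered here, and "the series" means these few. Any claim that something is new, unique, unknown or untested is made for them only; others in the source may bear on it.

Compound 1 `COc1cc(OC)cc(C(=CC#N)c2ccc(OC)c(O)c2)c1` stands second highest of the three numbers in a functional assay on HCT-116 cells (Homo sapiens) for cytotoxicity, read by scintillation counting and thymidine incorporation, with a stated time of 72 h (a lower number here means a stronger inhibitor, a higher number a weaker inhibitor), where compound 1 gives 2.5 nM. Its nearest neighbour is compound 3 `COc1cc(OC)cc(C(=CC#N)c2ccc(OC)c(N)c2)c1`, which gives 1.4 nM; the step of a 1.8-fold lower number from compound 1 to compound 3 (0.25 log units; within the scatter) lies within the scatter. Compound 2 `CCOc1cc(C(=CC#N)c2cc(OC)cc(OC)c2)ccc1OC` gives 34 nM, and the step of a 14-fold higher number from compound 1 to compound 2 (1.13 log units; beyond the scatter) is large, as is the step of a 24-fold lower number from compound 2 to compound 3 (1.39 log units; beyond the scatter). Compound 4 `COc1cc(OC)cc(C(=Cc2ccccc2)c2ccc(OC)c(O)c2)c1` differs from compound 1 by phenyl in place of cyano on a double-bonded chain carbon bound to a double-bonded chain carbon. For the measured compounds named here, none of the measured steps bears on this position: each of them alters a substituent on an aromatic ring, and the cyano on the double-bonded chain carbon is kept in compounds 1, 2 and 3 alike. The measured steps thus give no direct guide, and the estimate for compound 4 must carry a wide range. Compound 4 is expected to give 60 nM in this assay, between 5 nM and 800 nM, an expected step of a 24-fold higher number from compound 1 to compound 4 (1.38 log units; beyond the scatter) toward a weaker inhibitor.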

Compound 4, half-maximal inhibitory concentration: > 10000 nM
Compound 4 ended at the assay's limit; the forecaster's own chance of this, stated with the estimate: 10%; middle value at least 160-fold (2.22 log units) away from the limit.
By their numbers in this assay, from the lowest: compounds 3 and 1 (each within the scatter of the next); then compound 2. At a limit, above all of these: compound 4.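

Compound 4 reads > 10000 nM in this assay, which is a limit of the assay and not a number: the limit of > 10000 nM in this assay, at which 1 of the 4 values shown sits.

Phenyl in place of cyano on a double-bonded chain carbon bound to a double-bonded chain carbon gives an at least 4000-fold higher number from compound 1 to compound 4 (3.60 log units; beyond the scatter). This position, which holds cyano in compounds 1, 2 and 3, therefore matters greatly in this assay, and the step is larger than either large step printed for a ring substituent.

A single exchange cannot show whether the loss comes from removing cyano or from adding phenyl. On these data alone, how a methyl, a carboxylic acid or a primary amide on that same carbon would read remains open, as does whether any group other than cyano keeps the activity of compound 1.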